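This account rests on a few compounds, and the source may have more. Where it says the series, first, only, none or still open, it means among the compounds named here.

Of the compounds shown here, three built on one shared core have been measured in a functional assay on NIH3T3 cells (Mus musculus); on this read-out higher numbers stand for an effect only at larger amounts of compound and lower numbers for an effect already at smaller amounts. Compound 1 `Cn1cncc1C(OCc1ccc(C#N)cc1-c1ccccc1)c1ccc(C#N)cc1`, which carries a phenyl group, gives 140 nM. Compound 2 `Cn1cncc1C(OCc1ccc(C#N)cc1C#Cc1ccc(C#N)cc1)c1ccc(C#N)cc1`, with 2-(4-cyanophenyl)ethynyl in that place, gives 11.6 nM, and compound 3 `Cn1cncc1C(OCc1ccc(C#N)cc1C#CCCCCO)c1ccc(C#N)cc1`, with 6-hydroxyhex-1-yn-1-yl, gives 20.9 nM. Compound 2 thus stands at the low end of these numbers, level with compound 3 within the scatter, and well clear of compound 1.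

The next structure is compound 4 `Cn1cncc1C(OCc1ccc(C#N)cc1/C=C/c1ccc([N+](=O)[O-])cc1)c1ccc(C#N)cc1`, where 2-(4-nitrophenyl)ethenyl replaces 2-(4-cyanophenyl)ethynyl on an aromatic carbon: 2-(4-nitrophenyl)ethenyl in place of 2-(4-cyanophenyl)ethynyl on an aromatic carbon. Going by the values given here, three measured steps bear on this change. The first two are large or modest: a 12-fold lower number from compound 1 to compound 2 (1.08 log units; beyond the scatter), and a 6.7-fold lower number from compound 1 to compound 3 (0.83 log units; beyond the scatter). The third replaces the far end of the group and stays small: a 1.8-fold higher number from compound 2 to compound 3 (0.26 log units; within the scatter). Among the compounds with values here, in this small set, then, the end group of the chain has mattered little, yet no measured compound tests a double bond in place of a triple bond, nor a nitro group. No step beyond the scatter is therefore expected, with a slight upward lean at most. The expected change is a 1.7-fold higher number from compound 2 to compound 4 (0.24 log units; within the scatter). For compound 4 the estimate is 20 nM, with an expected range from 6 nM to 70 nM.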

Compound 4, half-maximal effective concentration: 2.24 nM
For compound 4 the middle estimate is 8.9-fold (0.95 log units) above the measured one; measured number outside the range, below it.
By their numbers in this assay, from the lowest: compound 4; then compounds 2 and 3 (each within the scatter of the next); then compound 1.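

In this assay, the change at this aromatic carbon, ortho to a large group and meta to a cyano group, gives a 5.2-fold lower number from compound 2 to compound 4 (0.71 log units; beyond the scatter) and so goes beyond the scatter, which shows that the group extending from this carbon can still shift the number even though the earlier step from the cyanophenyl group to the hydroxy chain stayed within it. Measured against the chain of compound 3, the new group gives a 9.3-fold lower number from compound 3 to compound 4 (0.97 log units; beyond the scatter) in this assay, and measured against the plain phenyl group it gives a 63-fold lower number from compound 1 to compound 4 (1.80 log units; beyond the scatter) as the largest step in the set, so 2-(4-nitrophenyl)ethenyl is the one group shown here that stands clear of all the others at this position. Nothing on hand explains this difference.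

The step swaps the triple bond for a double bond and the cyano group for a nitro group at the same time, and no pair of compounds shown separates these two changes. Going by these compounds, how an amine or a carboxylic acid at the far end of the group would read remains open, as does a longer chain carrying the aromatic ring.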